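Removing the Ring Methyl: Compound 1 to Compound 3

This account rests on a few compounds, and the source may have more. Where it says the series, first, only, none or still open, it means among the compounds named here.

Compound 1 `CC(C)C(CC1C(=O)NC(=O)N1C)c1ccc(-c2ccc3cccc(F)c3c2)[nH]c1=O` gives 65 nM in a functional assay on CHO cells for antagonist activity at prostaglandin E2 receptor EP3 subtype (Homo sapiens), read by cAMP accumulation, with a stated time of 30 min; a lower number here means a stronger inhibitor, a higher number a weaker inhibitor.
Compound 2 `CCC(/C=C1\OC(=O)NC1=O)(CC)c1ccc(-c2ccc3cccc(C(F)(F)F)c3c2)[nH]c1=O` gives "not determined" (no result reported) in this assay, that is, no result is reported for it.

For the measured compounds named here, compound 1 is therefore the only compound here with a measured number in this assay; compound 2 carries a different side chain and a different substituent on its outer ring, and no value is known for it, so nothing can be said about how the two compare.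

Compound 3 `CC(C)C(CC1NC(=O)NC1=O)c1ccc(-c2ccc3cccc(F)c3c2)[nH]c1=O` is the next compound to be tested. It differs from compound 1 in one place only: hydrogen in place of methyl on an amide-type nitrogen in a ring. Going by the values given here, no step between two measured compounds is available to show what such a change does in this assay, so the expectation rests on the single number for compound 1 alone. A change this small is expected to shift the value by an amount that may not exceed the usual scatter, in either direction, so the step of a 1.1-fold lower number from compound 1 to compound 3 (0.03 log units; within the scatter) is estimated to be modest. Compound 3 is expected to give about 60 nM, with a likely range from 20 nM to 200 nM.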

Compound 3, half-maximal inhibitory concentration: 31 nM
For compound 3 the middle estimate is 1.9-fold (0.29 log units) above the measured one; low and high end bracket the measured number.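

For the compounds shown here, this is the first step between two measured compounds, and it shows that the methyl on this ring nitrogen is not required for activity in this assay: the change gives a 2.1-fold lower number from compound 1 to compound 3 (0.32 log units; beyond the scatter). The size of the step is modest, but it lies beyond the usual scatter, so in this pair a hydrogen in place of the methyl gives the stronger inhibitor. Nothing measured here accounts for the shift, so the reason for it remains unknown.

The compounds shown leave open what a larger group on the same nitrogen, such as an ethyl or an acetyl group, would do to the number. They also leave open whether the same step would appear if the fluorine on the outer ring were replaced by chlorine.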